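Vinyl to Phenyl Exchange Tested Against a Cell Growth Limit

The source may report more compounds than this note shows. Statements on the series, on what has been measured and on what is new or still open speak of the compounds shown alone.

Compound 1 `C=CCONC(=O)CN1C(=O)S/C(=C\c2ccc(C(=O)N[C@@H](CC(C)C)C(=O)OC)cc2)C1=O` in a functional assay on MRC5 cells (Homo sapiens) for inhibition, read by microscopy and resazurin assay, with a stated time of 72 h (a lower number here means a stronger inhibitor, a higher number a weaker inhibitor), gives > 128000 nM, a limit of the assay.
Compound 2 `COC(=O)[C@H](CC(C)C)NC(=O)c1ccc(/C=C2\SC(=O)N(CC(=O)NOCc3ccccc3)C2=O)cc1` in this assay gives > 128000 nM, a limit of the assay.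
Compound 3 `C=CCONC(=O)CN1C(=O)S/C(=C\c2cccc(C(=O)N[C@H](C(=O)OC)C(C)C)c2)C1=O` in this assay gives > 128000 nM, a limit of the assay.

Compound 1 and compound 2 differ by phenyl in place of vinyl on a saturated chain carbon bound to an oxygen on an unsaturated carbon. The step that the two limits leave unreadable from compound 1 to compound 2 cannot be read, because of the limit of > 128000 nM in this assay, at which 3 of the 3 values shown sit. The difference between the core of compound 1 and the core of compound 3 is not broken down here. Compound 4 `COC(=O)[C@@H](NC(=O)c1cccc(/C=C2\SC(=O)N(CC(=O)NOCc3ccccc3)C2=O)c1)C(C)C` is not yet measured; it differs from compound 3 by phenyl in place of vinyl on a saturated chain carbon bound to an oxygen on an unsaturated carbon, the same change, at the same place, as from compound 1 to compound 2. Since compound 1, compound 2 and compound 3 all sit at the limit, the step that the limit leaves unreadable from compound 3 to compound 4 is expected to be small or unreadable. Compound 4 is therefore estimated at 200000 nM in this assay, most likely again reported only as a limit.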

Compound 4, half-maximal inhibitory concentration: > 128000 nM
Compound 4 ended at the assay's limit; the forecaster's own chance of this, stated with the estimate: 90%; the middle value does not contradict the limit.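

No new step can be read from compound 3 to compound 4, since both sit at the same assay limit: the limit of > 128000 nM in this assay, at which 4 of the 4 values shown sit. The compounds shown leave open whether the exchange of vinyl for phenyl changes inhibition at all.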